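Methyl for Hydroxy: One Change on a Shared Core

The source may report more compounds than this note shows. Statements on the series, on what has been measured and on what is new or still open speak of the compounds shown alone.

Going by the values given here, in a functional assay with Rattus norvegicus as the target (on this read-out higher numbers stand for weaker inhibition and lower numbers for stronger inhibition), compound 1 `O=c1[nH]c2ccc(O)cc2oc1=O` gives 170000 nM, the highest of the two numbers measured so far. Compound 2 `O=c1[nH]c2cc([N+](=O)[O-])ccc2oc1=O` gives 800 nM in this assay, a lower number that lies beyond the usual scatter. Compound 3 `Cc1ccc2[nH]c(=O)c(=O)oc2c1` differs from compound 1 by methyl in place of hydroxy on an aromatic carbon. Among the compounds with values here, no measured pair shows this particular change, so the expectation rests on the two values alone. Compound 3 is expected to give 50000 nM in this assay, with a range from 10000 nM to 200000 nM. The estimated step of a 3.4-fold lower number from compound 1 to compound 3 (0.53 log units; beyond the scatter) is thus a modest move toward a lower number, only just beyond the scatter.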

Compound 3, half-maximal inhibitory concentration: 32000 nM
Compound 3: the middle estimate sits 1.6-fold (0.19 log units) above what was measured, and the stated range covers the measured number.
By their numbers in this assay, from the lowest: compound 2; then compound 3; then compound 1.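

In this assay, going by these compounds alone, methyl in place of hydroxy on this aromatic carbon gives a 5.3-fold lower number from compound 1 to compound 3 (0.73 log units; beyond the scatter), the first single change on the shared core that can be read as a step. Methyl counts no hydrogen-bond donor or acceptor, so the donor and acceptor of hydroxy are not required at this position for a number lower than that of compound 1. Nothing measured here bears on why the number falls. Going by these compounds, whether an amine, a methoxy group or a longer alkyl chain on the same carbon would lower the number further remains open.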